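The source may report more compounds than this note shows. Statements on the series, on what has been measured and on what is new or still open speak of the compounds shown alone.

Of the compounds shown here, three built on one shared core have been tested in a functional assay on HeLa cells (Homo sapiens) for antiproliferative activity, read by CCK-8 assay, with a stated time of 72 h, tested at 8 uM; a higher number here means a stronger effect of the compound at the concentration tested, a lower number a weaker effect. Compound 1 `Nc1ccccc1NC(=O)c1ccc(CSC(=S)N2CCN(Cc3ccccn3)CC2)cc1` gives 61.4%, the second highest of the three numbers. Compound 2 `CN(C(=S)SCc1ccc(C(=O)Nc2ccccc2N)cc1)c1cccnc1` gives 70.5%, which lies within the usual scatter of compound 1. Compound 3 `Nc1ccccc1NC(=O)c1ccc(CSC(=S)N2CCCc3ccccc32)cc1` gives 35.7%, beyond the scatter and below compound 1. Within the data shown here, the only single-point step seen so far, a number 34.8 percentage points lower from compound 2 to compound 3 (beyond the scatter), alters the group on the thiocarbonyl carbon, not the amine nitrogen in a ring changed here. Compound 4 `N#Cc1ccc(N2CCN(C(=S)SCc3ccc(C(=O)Nc4ccccc4N)cc3)CC2)cc1` differs from compound 1 by 4-cyanophenyl in place of (pyridin-2-yl)methyl on an amine nitrogen in a ring. Among the measured compounds shown here, no measured step matches this change, so in this assay a step within the scatter is expected, a number 3.4 percentage points lower from compound 1 to compound 4 (within the scatter). Compound 4 is therefore estimated at 58%, between 40% and 75%.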

Compound 4, a percentage reported as inhibition, at one concentration (the size of the read-out at that concentration, not a potency): 70.6%
Estimate against measurement, compound 4: 12.6 percentage points below, within the range that was stated.
By their numbers in this assay, from the lowest: compound 3; then compounds 1, 2 and 4 (each within the scatter of the next).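

In this assay, 4-cyanophenyl in place of (pyridin-2-yl)methyl on the amine nitrogen in the ring gives a number 9.2 percentage points higher from compound 1 to compound 4 (within the scatter), so this step cannot be told apart from repeat-measurement noise. At this position, an aromatic ring of carbon only with a nitrile serves as well as the pyridine-bearing group. Nothing available explains this result. Still open, going by these compounds, is what a plain phenyl on this nitrogen would give, without the nitrile. On these data alone, a small methyl or a phenyl bearing a carboxylic acid is equally open.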